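This account rests on a few compounds, and the source may have more. Where it says the series, first, only, none or still open, it means among the compounds named here.

Three compounds that share one core were tested in an ADME assay on isolated protein for inhibition of peroxidase (Raphanus sativus), read by fluorescence and Amplex Red, tested at 5 uM; a lower number here means a stronger effect, a higher number a weaker effect of the compound at the concentration tested. Compound 1 `S=C(Nc1ccccc1)Nc1ccc2[nH]ccc2c1` gives 81.4%. Compound 2 `Oc1ccc(NC(=S)Nc2ccc3[nH]ccc3c2)cc1` gives 41.5%, and compound 3 `CC(=O)c1ccc(NC(=S)Nc2ccc3[nH]ccc3c2)cc1` gives 66.3%. Compound 3 thus stands second highest of the three numbers: its value lies a number 15.1 percentage points lower from compound 1 to compound 3 (beyond the scatter), which is a modest step downward, and a number 24.8 percentage points higher from compound 2 to compound 3 (beyond the scatter), a modest step upward.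

Compound 4 `CC(=O)Nc1ccc(NC(=S)Nc2ccc3[nH]ccc3c2)cc1` is the next compound in this line, and it differs from compound 3 in one place: acetamido in place of acetyl on an aromatic carbon. The entering group carries one hydrogen-bond donor, a feature compound 3 lacks and compound 2 has in its hydroxy.

Among the measured compounds shown here, two measured steps bear on this change. Putting acetyl in place of hydrogen gave a number 15.1 percentage points lower from compound 1 to compound 3 (beyond the scatter), a modest fall. Putting hydroxy in place of hydrogen gave a number 39.9 percentage points lower from compound 1 to compound 2 (beyond the scatter), a large fall, so the compound bearing a donor sits lowest. Removing that donor, a number 24.8 percentage points higher from compound 2 to compound 3 (beyond the scatter), brought the number back up modestly. Compound 4 is therefore expected to sit below compound 3, with a step of a number 11.3 percentage points lower from compound 3 to compound 4 (beyond the scatter), larger than the scatter but not as deep as compound 2. The estimate for compound 4 is 55%, with a range from 38% to 72%.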

Compound 4, a percentage reported as activity, at one concentration (the size of the read-out at that concentration, not a potency): 68.1%
Compound 4: middle estimate off by 13.1 percentage points, on the low side, within the range that was stated.
By their numbers in this assay, from the lowest: compound 2; then compounds 3 and 4 (each within the scatter of the next); then compound 1.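

In this assay, acetamido in place of acetyl on this aromatic carbon, para to a large group, gives a number 1.8 percentage points higher from compound 3 to compound 4 (within the scatter), so this change makes no difference that can be told from the usual scatter. A hydrogen-bond donor in the entering group is therefore not enough on its own to bring the number close to that of the hydroxy compound: acetamido and hydroxy both carry one, yet acetamido in place of hydroxy gives a number 26.6 percentage points higher from compound 2 to compound 4 (beyond the scatter). Acetamido in place of hydrogen gives a number 13.3 percentage points lower from compound 1 to compound 4 (beyond the scatter), a modest fall like the one seen with acetyl, which leaves hydroxy as the only group among these compounds to give a large fall.

No measurement shown here explains why hydroxy stands apart from the other two groups. On these data alone, it remains open whether that result is specific to hydroxy or extends to other groups at this place, such as methoxy, an amine or a carboxylic acid, and these would show whether the free hydroxy itself is what matters.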